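The source may hold more compounds than are shown below. What is called first, only, known or untested is meant among the compounds shown, and "the series" means these compounds.

Three amides built on one shared core have been tested in a functional assay on C8166 cells (Homo sapiens) for cytotoxicity, read by MTT assay; a lower number here means that less compound is tolerated, a higher number that more compound is tolerated. Compound 1 `Cc1ccc(C(=O)Nc2cc(Cl)ccc2OCC(=O)Nc2ccc(S(N)(=O)=O)cc2C)cc1C`, with 3,4-dimethylphenyl on the carbonyl carbon, gives 84100 nM. Compound 2 `Cc1cc(S(N)(=O)=O)ccc1NC(=O)COc1ccc(Cl)cc1NC(=O)c1cc(Cl)cc(C#N)c1`, with 3-chloro-5-cyanophenyl at that place, gives 131000 nM. Compound 3 `Cc1cc(S(N)(=O)=O)ccc1NC(=O)COc1ccc(Cl)cc1NC(=O)/C=C/c1ccccc1`, with 2-phenylethenyl there, gives 163000 nM. On these numbers compound 3 stands level with the other two, so no order can be claimed among the three.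

The next structure is compound 4 `Cc1cc(S(N)(=O)=O)ccc1NC(=O)COc1ccc(Cl)cc1NC(=O)c1cccc2ccccc12`, where naphthalen-1-yl takes the place of 2-phenylethenyl on a carbonyl carbon: naphthalen-1-yl in place of 2-phenylethenyl on a carbonyl carbon. The best guide is what earlier swaps at this same place have done. They gave a 1.6-fold higher number from compound 1 to compound 2 (0.19 log units; within the scatter), then a 1.9-fold higher number from compound 1 to compound 3 (0.29 log units; within the scatter), and finally a 1.2-fold higher number from compound 2 to compound 3 (0.09 log units; within the scatter). All three are small, and none leaves the scatter. No tested compound yet carries naphthalen-1-yl, so this guide is indirect, but it gives no reason to expect a step beyond the scatter in this assay. The expected step is small, with an estimate of a 1.4-fold lower number from compound 3 to compound 4 (0.13 log units; within the scatter). For compound 4 the estimated value is 120000 nM, with an expected range of 65000 nM to 220000 nM.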

Compound 4, half-maximal cytotoxic concentration: > 381000 nM
Compound 4: no number, only a limit (the forecaster's own chance of this, stated with the estimate: 15%); middle value at least 3.1-fold (0.50 log units) away from the limit.
By their numbers in this assay, from the lowest: compounds 1, 2 and 3 (each within the scatter of the next). At a limit, above all of these: compound 4.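

In this assay compound 4 gives a limit and not a number: the limit of > 381000 nM in this assay, at which 1 of the 4 values shown sits. Naphthalen-1-yl brings the first steps at this place that lie beyond the scatter, with an at least 2.3-fold higher number from compound 3 to compound 4 (0.36 log units; beyond the scatter) and also an at least 2.9-fold higher number from compound 2 to compound 4 (0.46 log units; beyond the scatter) and also an at least 4.5-fold higher number from compound 1 to compound 4 (0.65 log units; beyond the scatter) in the same direction. Each step is read from a limit and marks only a floor, yet it shows that the group on this carbonyl carbon can shift how much compound the cells tolerate, which the three earlier amides, all within the scatter of their neighbours, could not show.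

The swap from compound 3 to compound 4 removes a double bond outside aromatic rings and adds a second six-membered aromatic ring in a single change, and the compounds shown cannot separate these two differences or say how far past its limit compound 4 lies. They also leave open how this place responds to a naphthalen-2-yl group, a saturated cyclohexyl ring, an amine or a carboxylic acid.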